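Pyrazole chalcones against MCF7 cells: a dimethoxyphenyl rearrangement

A few compounds are considered here, and "the series" means these few. Any claim that something is new, unique, unknown or untested is made for them only; others in the source may bear on it.

Measured compounds:
compound 1 `COc1ccc(OC)c(C(=O)/C=C/c2cn(-c3ccccc3)nc2-c2ccsc2)c1` — 400 nM
compound 2 `COc1ccc(C(=O)/C=C/c2cn(-c3ccccc3)nc2-c2cccnc2)cc1OC` — 1700 nM

Of the compounds shown here, two have been measured in a functional assay on MCF7 cells (Homo sapiens) for inhibition, read by sulforhodamine B assay, with a stated time of 72 h; a lower number here means a stronger inhibitor, a higher number a weaker inhibitor. Compound 1 gives 400 nM in this assay. Compound 2, which carries a different aromatic ring on the core and a different dimethoxyphenyl pattern on the carbonyl, gives 1700 nM in this assay, the higher of the two numbers, and its gap to compound 1 is beyond the scatter. Because compound 1 and compound 2 differ in two places at once, the numbers alone do not say which change carries the gap.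

Compound 3 `COc1ccc(OC)c(C(=O)/C=C/c2cn(-c3ccccc3)nc2-c2cccnc2)c1` is not yet measured. It differs from compound 2 in one place: 2,5-dimethoxyphenyl in place of 3,4-dimethoxyphenyl on a carbonyl carbon. The same dimethoxyphenyl arrangement is present in compound 1, whose value in this assay, 400 nM, is the lower of the two. On that basis a downward step is expected, a 1.9-fold lower number from compound 2 to compound 3 (0.28 log units; within the scatter), though its size is uncertain since the ring on the core also differs between compound 1 and compound 2. For compound 3 the expected value in this assay is 900 nM, with a range from 300 nM to 2500 nM.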

Compound 3, half-maximal inhibitory concentration: 1500 nM
Estimate against measurement, compound 3: 1.7-fold (0.22 log units) below; the measured number falls inside the stated range.
By their numbers in this assay, from the lowest: compound 1; then compounds 3 and 2 (each within the scatter of the next).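

In this assay, 2,5-dimethoxyphenyl in place of 3,4-dimethoxyphenyl on a carbonyl carbon, with pyridin-3-yl held constant, gives a 1.1-fold lower number from compound 2 to compound 3 (0.05 log units; within the scatter) and so makes no readable difference in this pair. The other single change, pyridin-3-yl in place of thiophen-3-yl on an aromatic carbon with 2,5-dimethoxyphenyl held constant, gives a 3.8-fold higher number from compound 1 to compound 3 (0.57 log units; beyond the scatter) and so points to the ring on the core, rather than the dimethoxyphenyl pattern, as the change tied to the gap between compound 1 and compound 2 that could not be assigned before. Nothing available here offers a measured reason for either step.

The compounds shown leave open whether the dimethoxyphenyl pattern would be equally silent with thiophen-3-yl on the core, since the one comparison of the two patterns has pyridin-3-yl there. They also leave open what a hydroxyl group or an amine would do in place of the methoxy groups, and how a furan ring would compare with thiophen-3-yl at the same place on the core.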